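Cinnamamide aryl variation on the shared quinoline core

The source may report more compounds than this note shows. Statements on the series, on what has been measured and on what is new or still open speak of the compounds shown alone.

Measured so far:
- compound 1, `CCCc1cc(N)c2cc(NC(=O)/C=C/c3ccc(N)cc3)ccc2n1`: 190 nM
- compound 2, `CCCc1cc(N)c2cc(NC(=O)/C=C/c3ccccc3Cl)ccc2n1`: 120 nM

Both numbers come from an assay on isolated protein for displacement of a labelled ligand from melanin-concentrating hormone receptor 1 (Homo sapiens); on this read-out higher numbers stand for weaker inhibition and lower numbers for stronger inhibition. Among the measured compounds shown here, compound 2 has the lowest of the two numbers, but its only neighbour is compound 1, and the gap between them, a 1.6-fold lower number from compound 1 to compound 2 (0.20 log units; within the scatter), lies within the scatter, so no ordering of the two can be claimed on this assay.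

Compound 3, `CCCc1cc(N)c2cc(NC(=O)/C=C/c3ccc(SC)cc3)ccc2n1`, is not yet measured. Relative to compound 2 the change is 4-(methylsulfanyl)phenyl in place of 2-chlorophenyl on a double-bonded chain carbon bound to a double-bonded chain carbon. For the measured compounds named here, the only measured step that touches the same position is the one from compound 1 to compound 2, a swap of 4-aminophenyl for 2-chlorophenyl, and it stayed within the scatter on this assay. Going by the values given here, nothing beyond that single step informs the new aryl group; no measured compound carries a methylsulfanyl substituent. On that basis compound 3 is expected to sit close to compound 2, with an expected step of a 1.3-fold higher number from compound 2 to compound 3 (0.10 log units; within the scatter), in no direction beyond the scatter. The estimate for compound 3 on this assay is 150 nM, within a range of 50 nM to 450 nM.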

Compound 3, half-maximal inhibitory concentration: 9 nM
For compound 3 the middle estimate is 17-fold (1.22 log units) above the measured one; the whole stated range lies above it.
By their numbers in this assay, from the lowest: compound 3; then compounds 2 and 1 (each within the scatter of the next).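

In this assay, among the compounds shown here, this position, on a double-bonded chain carbon bound to a double-bonded chain carbon, proves far more responsive than the earlier pair suggested: entry of 4-(methylsulfanyl)phenyl in place of 2-chlorophenyl gives a 13-fold lower number from compound 2 to compound 3 (1.12 log units; beyond the scatter) while the only earlier step here stayed within the scatter. The exchange of a single substituent on the aromatic carbon is also enough for a large change, since methylsulfanyl in place of amino gives a 21-fold lower number from compound 1 to compound 3 (1.32 log units; beyond the scatter) with the rest of the structure held constant. The series therefore contains one clear gain at this position, and no available measurement bears on what lies behind it.

The compounds shown do not settle whether the gain belongs to the sulfur atom, to the methylsulfanyl group as a whole, or to the substituent's location on the ring, as 4-(methylsulfanyl)phenyl and 2-chlorophenyl differ in both name and numbering. Methoxy, ethylsulfanyl and methylsulfonyl groups on the same aromatic carbon remain open tests of how specific the value of compound 3 at 9 nM is to methylsulfanyl.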